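Catechol Swap Tested in a Cell Viability Series

The source may report more compounds than this note shows. Statements on the series, on what has been measured and on what is new or still open speak of the compounds shown alone.

Compounds measured so far:
compound 1, `O=C(CSc1nnc(-c2ccncc2)o1)N/N=C/c1ccc(O)cc1`, 5510 nM
compound 2, `O=C(CSc1nnc(-c2ccncc2)o1)N/N=C/c1cc(Cl)ccc1O`, 3970 nM

Compound 2 gives the lowest number of the two measured in a functional assay on HepG2 cells (Homo sapiens) for cytotoxicity, read by MTT assay, with a stated time of 48 h (a higher number here means a weaker inhibitor, a lower number a stronger inhibitor), but its neighbour compound 1 is separated from it only by a 1.4-fold lower number from compound 1 to compound 2 (0.14 log units; within the scatter), a gap within the scatter, so the two cannot be ranked.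

Compound 3, `O=C(CSc1nnc(-c2ccncc2)o1)N/N=C/c1ccc(O)c(O)c1`, is not yet measured. It differs from compound 2 by 3,4-dihydroxyphenyl in place of 5-chloro-2-hydroxyphenyl on a carbon with a double bond to nitrogen. Among the compounds with values here, the only step that bears on this position is the one from compound 1 to compound 2, where the aromatic substituent on the same carbon was exchanged and the number moved by a 1.4-fold lower number from compound 1 to compound 2 (0.14 log units; within the scatter), within the scatter. On that basis no shift beyond the scatter is expected for compound 3 in this assay, so the step is estimated as a 1.1-fold higher number from compound 2 to compound 3 (0.02 log units; within the scatter).

For compound 3 the expected value in this assay is 4200 nM, with a range from 1500 nM to 12000 nM.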

Compound 3, half-maximal inhibitory concentration: 760 nM
Compound 3: the middle estimate sits 5.5-fold (0.74 log units) above what was measured; the measured number lies below the stated range.
By their numbers in this assay, from the lowest: compound 3; then compounds 2 and 1 (each within the scatter of the next).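

In this assay, this position proved able to move the number well beyond the scatter: with 3,4-dihydroxyphenyl on the carbon with a double bond to nitrogen, the series shows a 5.2-fold lower number from compound 2 to compound 3 (0.72 log units; beyond the scatter), whereas the earlier exchange there had stayed within the scatter. The cleaner comparison is hydroxy in place of hydrogen on an aromatic carbon, which gives a 7.3-fold lower number from compound 1 to compound 3 (0.86 log units; beyond the scatter), so this single change to the 4-hydroxyphenyl group is enough for a step beyond the scatter. Nothing available here explains why the number falls.

From the compounds shown here alone, whether the added hydroxy could be replaced by a methoxy group or an amine and keep the lower number remains open. So does whether a 3-hydroxyphenyl group alone would give a similar number.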